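A few compounds are considered here, and "the series" means these few. Any claim that something is new, unique, unknown or untested is made for them only; others in the source may bear on it.

Measured so far in a functional assay on HCT-116 cells (Homo sapiens); on this read-out lower numbers stand for stronger inhibition and higher numbers for weaker inhibition:
- compound 1 `COc1cc(NC(C)CCCNC(=O)NCCO)c2ncccc2c1`: > 100000 nM
- compound 2 `COc1cc(NC(C)CCCNC(=O)NCCCO)c2ncccc2c1`: > 100000 nM

Neither entry is a number. Compound 1 stands only at a limit, and the series as a whole rests on (the limit of > 100000 nM in this assay, at which 2 of the 2 values shown sit).

Compound 3 `COc1cc(NC(C)CCCNC(=O)NCCCCCO)c2ncccc2c1` keeps the core of compound 1 and changes only the end of the chain: 3-hydroxypropyl in place of hydroxy on a saturated chain carbon, two bonds along the chain from an amide-type nitrogen. Cut one bond further out, the same difference reads 2-hydroxyethyl to 5-hydroxypentyl.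

For the measured compounds named here, the one measured step that bears on this is a step that the two limits leave unreadable from compound 1 to compound 2, with hydroxymethyl in place of hydroxy at the same place. It gives no size to carry over and no direction. The step expected in this assay is a number no higher from compound 1 to compound 3 (the limit leaves the size open), with no clear move either way and most likely another limit. The estimate for compound 3 is 100000 nM, with an expected range of 40000 nM to 200000 nM.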

Compound 3, half-maximal inhibitory concentration: 29000 nM
Estimate against measurement, compound 3: 3.4-fold (0.54 log units) above; the whole stated range lies above it.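

For the compounds shown here, compound 3 gives the first readable value at this position in this assay, so the chain end can move this read-out. With 5-hydroxypentyl in place of 2-hydroxyethyl there is an at least 3.4-fold lower number from compound 1 to compound 3 (0.53 log units; beyond the scatter), and the second limit compound gives an at least 3.4-fold lower number from compound 2 to compound 3 (0.53 log units; beyond the scatter); both sizes are minimums, and both lie beyond the scatter. The step between the two earlier compounds cannot be read, so a change shows only at the 5-hydroxypentyl length, and the rest of the series stays at a limit: the limit of > 100000 nM in this assay, at which 2 of the 3 values shown sit.

From the compounds shown here alone, how the read-out runs at 4-hydroxybutyl, or with a longer chain, stays open. Also open, going by these compounds, is whether the terminal hydroxy matters, which an amine or a carboxylic acid at the end of the same chain would separate from chain length.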